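The source may report more compounds than this note shows. Statements on the series, on what has been measured and on what is new or still open speak of the compounds shown alone.

Of the compounds shown here, three of the shared core have been measured in a physicochemical assay for solubility, read by HPLC; a higher number here means a more soluble compound, a lower number a less soluble compound. Compound 1 `CSCC(=O)N1CCN(c2nc(=O)c3cc(C(F)(F)F)cc([N+](=O)[O-])c3s2)CC1` gives 15.2 ug/mL, compound 2 `CC1COC2(CCN(c3nc(=O)c4cc(C(F)(F)F)cc([N+](=O)[O-])c4s3)CC2)O1` gives 0.94 ug/mL, and compound 3 `O=C(c1ccccc1F)N1CCN(c2nc(=O)c3cc(C(F)(F)F)cc([N+](=O)[O-])c3s2)CC1` gives 3.1 ug/mL, the second highest of the three numbers. For the measured compounds named here, the only step so far at the carbonyl carbon, a 4.9-fold lower number from compound 1 to compound 3 (0.69 log units; beyond the scatter), ran downward. Compound 4 `CC(C)(C)C1CCC(C(=O)N2CCN(c3nc(=O)c4cc(C(F)(F)F)cc([N+](=O)[O-])c4s3)CC2)CC1` carries the change (4-(tert-butyl)cyclohexyl in place of 2-fluorophenyl on a carbonyl carbon). Going by the values given here, no measured pair shows this exact exchange; compound 2 and compound 3 differ in more than one place, so only their two values can be compared. Given that the one step on this carbonyl carbon fell, a further modest fall in this assay is expected, a 3.4-fold lower number from compound 3 to compound 4 (0.54 log units; beyond the scatter). Compound 4 is estimated at 0.9 ug/mL, range 0.25 ug/mL to 3 ug/mL.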

Compound 4, solubility: < 0.1 ug/mL
Compound 4: a limit, no number (the forecaster's own chance of this, stated with the estimate: 10%); middle value at least 9.0-fold (0.95 log units) away from the limit.
By their numbers in this assay, from the lowest: compound 2; then compound 3; then compound 1. At a limit, below all of these: compound 4.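

On this carbonyl carbon, 4-(tert-butyl)cyclohexyl in place of 2-fluorophenyl gives an at least 31-fold lower number from compound 3 to compound 4 (1.49 log units; beyond the scatter) in this assay, a large step and far steeper than the earlier one. Against the (methylsulfanyl)methyl group, the exchange gives an at least 150-fold lower number from compound 1 to compound 4 (2.18 log units; beyond the scatter), so this position alone spans a wide range of the series. Compound 4 sits at a limit and not a number, and the full size of both steps cannot be read: the limit of < 0.1 ug/mL in this assay, at which 1 of the 4 values shown sits.

The exchange alters ring type and group size together, and the compounds shown do not separate the two. Also open, from the compounds shown here alone, is how an amine or a carboxylic acid at this position would read in this assay.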